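This account rests on a few compounds, and the source may have more. Where it says the series, first, only, none or still open, it means among the compounds named here.

Compound 1 `CC[C@@H](C(=O)Nc1ccccc1)N1CCCC1=O` gives 560 umol/kg 
Compound 2 `CC[C@@H](C(=O)NO)N1CCCC1=O` gives 1000 umol/kg 
Compound 3 `CC[C@@H](C(=O)NN)N1CCCC1=O` gives 1000 umol/kg 

In a functional assay on the whole organism with Mus musculus as the target (on this read-out higher numbers stand for an effect only at larger amounts of compound and lower numbers for an effect already at smaller amounts), compound 3 reads the same as compound 2, and all three numbers lie within the usual scatter of one another. Compound 4 `CC[C@@H](C(=N)S)N1CCCC1=O` differs from compound 3 by a group of 3 heavy atoms (1 carbon, 1 nitrogen, 1 sulfur; no ring) in place of a group of 4 heavy atoms (1 carbon, 2 nitrogen, 1 oxygen; no ring), on a saturated chain carbon bound to an amide-type nitrogen in a ring and a saturated chain carbon and the group that leaves is aminocarbamoyl. The expectation for this change rests on three measured steps at the same place: a 1.8-fold higher number from compound 1 to compound 3 (0.25 log units; within the scatter) and a 1.8-fold higher number from compound 1 to compound 2 (0.25 log units; within the scatter) and no change at the digits printed from compound 2 to compound 3 (within the scatter) and none of them goes beyond the scatter. None of them brings in sulfur, so the evidence is only indirect. No step beyond the scatter is expected, and the estimated size is a 1.3-fold lower number from compound 3 to compound 4 (0.10 log units; within the scatter) in this assay at most a small move. Compound 4 is estimated at 800 umol/kg with an expected range from 350 umol/kg to 1600 umol/kg as its span.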

Compound 4, dose for half-maximal effect: 1000 umol/kg
Estimate against measurement, compound 4: 1.3-fold (0.10 log units) below; the measured number falls inside the stated range.
By their numbers in this assay, from the lowest: compounds 1, 2, 3 and 4 (each within the scatter of the next).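

In this assay, the sulfur-bearing group at this position gives no change at the digits printed from compound 3 to compound 4 (within the scatter) and no change at the digits printed from compound 2 to compound 4 (within the scatter). For the compounds shown here, compound 4 is the first compound here to carry sulfur at this place, and that swap moves the number no further than the scatter. No supporting data are available to explain this result.

As far as these compounds go, whether any group at this position can move the number beyond the scatter remains open. A carboxylic acid or an amine in place of the aminocarbamoyl group would be one test, and neither is among the compounds shown.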